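Same atoms, new arrangement: from compound 3 to compound 4

The source may report more compounds than this note shows. Statements on the series, on what has been measured and on what is new or still open speak of the compounds shown alone.

Three related compounds have been measured in a functional assay on K562 cells (Homo sapiens) for cytotoxicity, read by trypan blue exclusion, with a stated time of 96 h; on this read-out lower numbers stand for stronger inhibition and higher numbers for weaker inhibition. Compound 1 `COc1ccc(N)cc1CS(=O)(=O)/C=C/c1c(OC)cccc1OC` gives 25000 nM, compound 2 `COc1cc(OC)c(/C=C/S(=O)(=O)Cc2ccc(OC)cc2[N+](=O)[O-])c(OC)c1` gives 20000 nM, and compound 3 `COc1ccc(CS(=O)(=O)/C=C/c2c(OC)cc(OC)cc2OC)c(N)c1` gives 25 nM, the lowest of the three numbers and well beyond the scatter of the other two.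

Compound 4 `COc1cc(OC)c(/C=C/S(=O)(=O)Cc2cc(N)ccc2OC)c(OC)c1` has the same atoms as compound 3, joined differently: 5-amino-2-methoxyphenyl in place of 2-amino-4-methoxyphenyl on a saturated chain carbon bound to a sulfonyl sulfur. In words, 5-amino-2-methoxyphenyl takes the place of 2-amino-4-methoxyphenyl on a saturated chain carbon bound to a sulfonyl sulfur.

Going by the values given here, only one measured step bears directly on this part of the molecule: an 800-fold lower number from compound 2 to compound 3 (2.90 log units; beyond the scatter), with amino in place of nitro on an aromatic carbon. That step swaps one group for another rather than rearranging them, so it cannot predict this change, but it shows how large a change here can be. A second clue comes from the entering group itself, which compound 1 also carries, and compound 1 gives 25000 nM. Compound 1 differs from compound 4 elsewhere too, so this is only a hint.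

The expected change is a 40-fold higher number from compound 3 to compound 4 (1.60 log units; beyond the scatter), toward weaker inhibition and beyond the scatter, though its size is uncertain. For compound 4 the estimated value is 1000 nM, with an expected range from 50 nM to 20000 nM.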

Compound 4, half-maximal inhibitory concentration: 7500 nM
Estimate against measurement, compound 4: 7.5-fold (0.88 log units) below; the range from low to high includes it.
By their numbers in this assay, from the lowest: compound 3; then compound 4; then compounds 2 and 1 (each within the scatter of the next).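

In this assay, the earlier amino-for-nitro swap changed which group was present, whereas here every atom stays and only the ring's arrangement differs: 5-amino-2-methoxyphenyl replaces 2-amino-4-methoxyphenyl, giving a 300-fold higher number from compound 3 to compound 4 (2.48 log units; beyond the scatter). So carrying an amino and a methoxy group on this ring is not enough to give the low number of compound 3; how the two groups are arranged matters a great deal on this read-out. With 5-amino-2-methoxyphenyl in place, adding a methoxy in place of hydrogen on an aromatic carbon gives only a modest gain, a 3.3-fold lower number from compound 1 to compound 4 (0.52 log units; beyond the scatter), and no measurement here explains either step.

From the compounds shown here alone, it remains open whether the amino group of 2-amino-4-methoxyphenyl could be exchanged for a hydroxyl group, or its methoxy group for an ethoxy group or a chlorine atom, without losing the low number of compound 3. Going by these compounds, it is also open whether the same methoxy change on an aromatic carbon would stay modest when the ring attached to the saturated chain carbon is 2-amino-4-methoxyphenyl.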